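The source may hold more compounds than are shown below. What is called first, only, known or untested is meant among the compounds shown, and "the series" means these compounds.

In a functional assay on HepG2 cells (Homo sapiens) for inhibition, read by MTT assay, with a stated time of 3 days (a higher number here means a weaker inhibitor, a lower number a stronger inhibitor), compound 1 `COc1cc(-c2nc3ccccc3s2)ccc1OCC(=O)NNC(=O)CN[C@@H](CS)C(=O)O` gives 3120 nM, compound 2 `COc1cc(-c2nc3ccccc3s2)ccc1OCC(=O)NNC(=O)CN1CCC[C@H]1C(=O)O` gives 2650 nM, and compound 3 `CCOC(=O)CN(C)CC(=O)NNC(=O)COc1ccc(-c2nc3ccccc3s2)cc1OC` gives 3180 nM. Compound 3 therefore stands level with the other two: a 1.0-fold higher number from compound 1 to compound 3 (0.01 log units; within the scatter) and a 1.2-fold higher number from compound 2 to compound 3 (0.08 log units; within the scatter) both lie within the scatter, as does a 1.2-fold lower number from compound 1 to compound 2 (0.07 log units; within the scatter). Compound 4 `CCOC(=O)[C@H](CS)N(CC(=O)NNC(=O)COc1ccc(-c2nc3ccccc3s2)cc1OC)C(C)=O` carries acetyl(1-(ethoxycarbonyl)-2-sulfanylethyl)amino in place of ((ethoxycarbonyl)methyl)(methyl)amino on a saturated chain carbon bound to a carbonyl carbon. Among the compounds with values here, its sulfanyl chain recalls compound 1 and its ester recalls compound 3, yet no measured compound carries the acetyl group, so the evidence is indirect. Since all the measured changes at this place stayed within the scatter, no shift beyond the scatter is expected in this assay. The expected size is a 1.1-fold lower number from compound 3 to compound 4 (0.03 log units; within the scatter). Compound 4 is estimated at 3000 nM, with an expected range from 1400 nM to 6500 nM.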

Compound 4, half-maximal inhibitory concentration: 3010 nM
For compound 4 the middle estimate is 1.0-fold (0.00 log units) below the measured one, and the stated range covers the measured number.
By their numbers in this assay, from the lowest: compounds 2, 4, 1 and 3 (each within the scatter of the next).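

In this assay, within the data shown here, acetyl(1-(ethoxycarbonyl)-2-sulfanylethyl)amino, the first group here to carry an acetyl, stays within the scatter of all three earlier compounds (a 1.1-fold lower number from compound 3 to compound 4 (0.02 log units; within the scatter); a 1.1-fold higher number from compound 2 to compound 4 (0.06 log units; within the scatter); a 1.0-fold lower number from compound 1 to compound 4 (0.02 log units; within the scatter)). The flat picture at this saturated chain carbon bound to a carbonyl carbon therefore extends to a group with an acetyl, an ester and a sulfanyl chain together. Nothing shown explains this absence of change. The compounds shown leave open whether any group here would move the number beyond the scatter, such as an unsubstituted amine or a longer chain ending in a carboxylic acid.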